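A Chlorine Added to a Phenyl Ring, Seen Twice

This account rests on a few compounds, and the source may have more. Where it says the series, first, only, none or still open, it means among the compounds named here.

Compound 1 `O=C(CSc1nc(-c2ccccc2)c(C(=O)O)c(=O)[nH]1)Nn1c(COc2ccc(Cl)cc2Cl)nc2ccccc2c1=O` and compound 2 `O=C(CSc1nc(-c2ccc(Cl)cc2)c(C(=O)O)c(=O)[nH]1)Nn1c(COc2ccc(Cl)cc2Cl)nc2ccccc2c1=O` share one core, while compound 3 `Cn1c(SCC(=O)Nn2c(COc3ccc(Cl)cc3Cl)nc3ccccc3c2=O)nc(-c2ccccc2)c(C#N)c1=O` and compound 4 `Cn1c(SCC(=O)Nn2c(COc3ccc(Cl)cc3Cl)nc3ccccc3c2=O)nc(-c2ccc(Cl)cc2)c(C#N)c1=O` share another; the difference between the two cores is not broken down here. In a functional assay on the whole organism (strain albino) for inhibition, with Rattus norvegicus as the target, read by paw edema, with stated times of 1 h and 0.5 h, at a dose of 100 mg/kg by the oral route (on this read-out higher numbers stand for more inhibition at the one dose given (going by the name of the read-out) and lower numbers for less inhibition), compound 1 gives 61.5%, and compound 2 gives 51.9%. The change between them is chloro in place of hydrogen on an aromatic carbon, and it made a step of a number 9.6 percentage points lower from compound 1 to compound 2 (within the scatter). In this assay compound 3 gives 51.9%, level with compound 2 at the digits reported. Compound 4 carries the same change on its own core, namely (chloro in place of hydrogen on an aromatic carbon), at a place described in the same words. For compound 4 the expected step is a number 6.9 percentage points lower from compound 3 to compound 4 (within the scatter), because the same change earlier gave a number 9.6 percentage points lower from compound 1 to compound 2 (within the scatter). Compound 4 is therefore estimated at 45%, with a likely range from 32% to 58%.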

Compound 4, a percentage reported as inhibition, in the whole organism at one dose (the size of the read-out at that dose, not a potency): 80.8%
The estimate for compound 4 lay 35.8 percentage points below the measured number; measured number above the stated range.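

In this assay, the change from phenyl to 4-chlorophenyl gave a number 28.9 percentage points higher from compound 3 to compound 4 (beyond the scatter), and set beside the earlier step it did not carry over from one core to the other: the same change on two cores in this assay, a number 9.6 percentage points lower (within the scatter) from compound 1 to compound 2 and a number 28.9 percentage points higher (beyond the scatter) from compound 3 to compound 4, 38.5 percentage points apart, beyond the scatter of two such steps

The earlier step lies within the scatter, so the firm result is a clear gain on one core and no clear change on the other. These two pairs do not show which difference between the cores matters, and they make no general rule for the series.

Going by these compounds, it remains open whether a methoxy group or an amine at the same place on the ring would also behave differently on the two cores. On these data alone, it also remains open how the chlorine would act on any further core.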